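Chain to Ring on the Aromatic Nitrogen, Toxicity Unchanged?

A few compounds are considered here, and "the series" means these few. Any claim that something is new, unique, unknown or untested is made for them only; others in the source may bear on it.

Of the compounds shown here, two sharing one core have been tested, and a third is awaiting its measurement. Compound 1 `CCCn1nc(C(=O)N[C@H]2COc3ccccc3N(C)C2=S)nc1Cc1ccccc1` carries a propyl chain on the aromatic nitrogen. In a toxicity assay on HT-29 cells (Homo sapiens) for cytotoxicity (on this read-out higher numbers stand for lower toxicity in this test and lower numbers for higher toxicity in this test), compound 1 gives > 100000 nM, which is a limit of the assay and not a number. Compound 2 `CN1C(=S)[C@@H](NC(=O)c2nc(Cc3ccccc3)n(CCCCCC#N)n2)COc2ccccc21` carries a longer chain on that same nitrogen. In this assay compound 2 gives > 100000 nM, again a limit rather than a number. The step that the two limits leave unreadable from compound 1 to compound 2 therefore cannot be read in size or direction. Among the measured compounds shown here, the one piece of evidence is the limit of > 100000 nM in this assay, at which 2 of the 2 values shown sit, so compound 2 stands at the limit alongside compound 1.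

Compound 3 `CN1C(=S)[C@@H](NC(=O)c2nc(Cc3ccccc3)n(C3CCOCC3)n2)COc2ccccc21` differs from compound 2 in one place: oxan-4-yl in place of 5-cyanopentyl on an aromatic nitrogen. For the measured compounds named here, the only measured step, from compound 1 to compound 2, is unreadable, so it gives no direction to expect here. With both known values at the limit, compound 3 is expected to show a step that the limit leaves unreadable from compound 2 to compound 3 and is most likely also to be reported as a limit. The estimate for compound 3 in this assay is 150000 nM, within a range from 40000 nM to 500000 nM.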

Compound 3, half-maximal cytotoxic concentration: > 100000 nM
Compound 3 ended at the assay's limit; the forecaster's own chance of this, stated with the estimate: 75%; the middle value lies beyond the limit too.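

Compound 1, compound 2 and compound 3 all sit at the same limit, which is not a number, so none of the steps among them can be read in size or direction in this assay: the limit of > 100000 nM in this assay, at which 3 of the 3 values shown sit.

The compounds shown leave open how far these three differ in toxicity, and whether any group on the aromatic nitrogen would give a value that is a number rather than a limit.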